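The source may hold more compounds than are shown below. What is called first, only, known or untested is meant among the compounds shown, and "the series" means these compounds.

Compound 1 `Cn1c(=O)c2ccccc2c(=O)n1CCCNC(=O)OC(C)(C)C` was tested in a functional assay on aorta (Rattus norvegicus, strain Wistar) for inhibition (on this read-out lower numbers stand for an effect already at smaller amounts and higher numbers for an effect only at larger amounts of compound), where compound 1 gives 3960 nM. Compound 2 `Cn1c(=O)c2cccc(Cl)c2c(=O)n1CCCNC(=O)OC(C)(C)C` carries chloro in place of hydrogen on an aromatic carbon; in this assay compound 2 gives 4780 nM, so the step is a 1.2-fold higher number from compound 1 to compound 2 (0.08 log units; within the scatter). Compound 3 `Cn1c(=O)c2ccccc2c(=O)n1CCN=[N+]=[N-]` rests on another core; the difference between the two cores is not broken down here. In this assay compound 3 gives 10000 nM, the highest of the three numbers, beyond the scatter from both compound 1 and compound 2. Compound 4 `Cn1c(=O)c2cccc(Cl)c2c(=O)n1CCN=[N+]=[N-]` has not yet been measured. Within the data shown here, it carries chloro in place of hydrogen on an aromatic carbon, the same change as the one between compound 1 and compound 2, at the same place. The expected step, a 1.2-fold higher number from compound 3 to compound 4 (0.08 log units; within the scatter), rests on the measured step of a 1.2-fold higher number from compound 1 to compound 2 (0.08 log units; within the scatter). Compound 4 is thus estimated at 12000 nM, between 6000 nM and 25000 nM.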

Compound 4, half-maximal effective concentration: 6350 nM
The estimate for compound 4 lay 1.9-fold (0.28 log units) above the measured number; the measured number falls inside the stated range.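

On the second core, chloro in place of hydrogen on an aromatic carbon gives a 1.6-fold lower number from compound 3 to compound 4 (0.20 log units; within the scatter) in this assay. Set beside the earlier step, the change carries from one core to the other with no difference that can be told from the scatter: the same change on two cores in this assay, a 1.2-fold higher number (0.08 log units; within the scatter) from compound 1 to compound 2 and a 1.6-fold lower number (0.20 log units; within the scatter) from compound 3 to compound 4, 1.9-fold (0.28 log units) apart, within the scatter of two such steps This shows only that on these two cores the step stays within the scatter; two pairs give no rule for other cores, and they do not show what the chloro group does in the assay.

The compounds shown leave open whether chloro behaves alike elsewhere on the aromatic ring, and what fluoro or methoxy would do in its place. They also leave open what an amine, a carboxylic acid or a longer chain would do on the side chain.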